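The source may report more compounds than this note shows. Statements on the series, on what has been measured and on what is new or still open speak of the compounds shown alone.

Among the compounds with values here, in an ADME assay on MDCKII-LE cells (Canis lupus familiaris) for permeability (a lower number here means that the compound crosses the layer more slowly, a higher number that the compound crosses the layer faster), compound 1 (`NC(=O)[C@@H](CCC(F)(F)F)N(CC12CC(c3ncon3)(C1)C2)S(=O)(=O)c1ccc(Cl)cc1`) gives 19.3 10^-6 cm/s and compound 2 (`N#CCCN([C@H](CCC(F)(F)F)C(N)=O)S(=O)(=O)c1ccc(Cl)cc1`) gives 10.2 10^-6 cm/s, which places compound 1 within the scatter of the only other compound measured. Compound 3 (`N#CCCCN([C@H](CCC(F)(F)F)C(N)=O)S(=O)(=O)c1ccc(Cl)cc1`) differs from compound 1 by a group of 4 heavy atoms (3 carbon, 1 nitrogen; no ring) in place of a group of 10 heavy atoms (7 carbon, 2 nitrogen, 1 oxygen; 2 four-membered non-aromatic rings of carbon only, one five-membered aromatic ring with 3 hetero atoms), on a saturated chain carbon bound to a sulfonamide nitrogen; the entering group is 2-cyanoethyl. The closest measured change is a 1.9-fold lower number from compound 1 to compound 2 (0.28 log units; within the scatter), where the same group also gives way to a small nitrile-bearing chain. A similar, modest drop is therefore expected, with the estimated change being a 1.6-fold lower number from compound 1 to compound 3 (0.21 log units; within the scatter), probably within the scatter. Compound 3 is estimated to give 12 10^-6 cm/s, with an expected range of 6 10^-6 cm/s to 22 10^-6 cm/s.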

Compound 3, apparent permeability: 27.6 10^-6 cm/s
The estimate for compound 3 lay 2.3-fold (0.36 log units) below the measured number; the measured number lies above the stated range.
By their numbers in this assay, from the lowest: compounds 2, 1 and 3 (each within the scatter of the next, the first and the last beyond it).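

In this assay, 2-cyanoethyl can take the place of the group carrying the four-membered rings and the five-membered aromatic ring without leaving the scatter (a 1.4-fold higher number from compound 1 to compound 3 (0.16 log units; within the scatter)). Within the data shown here, the chain itself still matters: cyanomethyl in place of cyano gives the only step of the three beyond the scatter (a 2.7-fold higher number from compound 2 to compound 3 (0.43 log units; beyond the scatter)). Nothing available explains this step. Still open, going by these compounds, is whether a longer nitrile chain would continue this rise, and how an amine or a carboxylic acid in place of the nitrile would read.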